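This account rests on a few compounds, and the source may have more. Where it says the series, first, only, none or still open, it means among the compounds named here.

Measured so far in a functional assay on HT-29 cells (Homo sapiens) for inhibition, read by MTT assay, with a stated time of 48 h; a lower number here means a stronger inhibitor, a higher number a weaker inhibitor:
compound 1 `Cc1ccc(NC(=S)NC(=O)c2ccc(OCc3cccc(Cl)c3)cc2)cc1-c1nc2ccccc2[nH]1` gives 35300 nM
compound 2 `Cc1ccc(NC(=S)NC(=O)c2ccc(OCc3ccc(C(F)(F)F)cc3)cc2)cc1-c1nc2ccccc2[nH]1` gives 17600 nM
compound 3 `Cc1ccc(NC(=S)NC(=O)c2ccc(OCc3ccccc3F)cc2)cc1-c1nc2ccccc2[nH]1` gives 1870 nM

Compound 3 stands lowest of the three, with both neighbours beyond the scatter: a 19-fold lower number from compound 1 to compound 3 (1.28 log units; beyond the scatter) and a 9.4-fold lower number from compound 2 to compound 3 (0.97 log units; beyond the scatter). Compound 4 `Cc1ccc(COc2ccc(C(=O)NC(=S)Nc3ccc(C)c(-c4nc5ccccc5[nH]4)c3)cc2)cc1` differs from compound 3 by 4-methylphenyl in place of 2-fluorophenyl on a saturated chain carbon bound to an oxygen on an aromatic ring. Going by the values given here, no measured pair carries a 4-methylphenyl, so the change itself is untested; what bears on it is that both departures from 2-fluorophenyl seen so far gave higher numbers in this assay, one large and one modest. Replacing 2-fluorophenyl is therefore expected to move the number up rather than down, by a modest step, a 4.8-fold higher number from compound 3 to compound 4 (0.68 log units; beyond the scatter). For compound 4 the estimate is 9000 nM, with a range from 2500 nM to 35000 nM.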

Compound 4, half-maximal inhibitory concentration: 14200 nM
The estimate for compound 4 lay 1.6-fold (0.20 log units) below the measured number; low and high end bracket the measured number.
By their numbers in this assay, from the lowest: compound 3; then compounds 4, 2 and 1 (each within the scatter of the next, the first and the last beyond it).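

In this assay, the 4-methylphenyl is a third group at this place that gives a higher number than 2-fluorophenyl, a 7.6-fold higher number from compound 3 to compound 4 (0.88 log units; beyond the scatter), and compound 3 remains apart from all the others. Methyl in place of trifluoromethyl on an aromatic carbon is the first single-substituent change at this place, and it stays within the scatter, a 1.2-fold lower number from compound 2 to compound 4 (0.09 log units; within the scatter), whereas the change from 3-chlorophenyl lies beyond it, a 2.5-fold lower number from compound 1 to compound 4 (0.40 log units; beyond the scatter). No available evidence bears on the reason for these differences.

The compounds shown leave open whether the number for compound 3 depends on fluorine itself or on the 2-fluorophenyl group as a whole. A plain phenyl or a pyridyl group at this place would bear on that question.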